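A New Group on the Shared Core

The compounds below may be only part of what the source reports. "The series", "measured", "known", "first", "only" and "open" are said of these compounds alone.

Compound 1 `CN(c1ncco1)c1cnc(NCc2c(F)ccc3c2CCO3)n2cnnc12` and compound 2 `CN(c1ccn(C)n1)c1cnc(NCc2c(F)ccc3c2CCO3)n2cnnc12` share one core and differ only in the aromatic ring carried on a nitrogen. In an ADME assay on the whole organism (Rattus norvegicus) for pharmacokinetics (on this read-out lower numbers stand for slow clearance and higher numbers for fast clearance), compound 1 gives 29 mL/min/kg, and compound 2 gives 29 mL/min/kg, so compound 2 stands level with compound 1. Among the measured compounds shown here, the only measured step is no change at the digits printed from compound 1 to compound 2 (within the scatter), with 1-methyl-1H-pyrazol-3-yl in place of 1,3-oxazol-2-yl.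

Compound 3 `O=C1CC2(CC2)CN1c1cnc(NCc2c(F)ccc3c2CCO3)n2cnnc12` carries a larger change: a group of 8 heavy atoms (6 carbon, 1 nitrogen, 1 oxygen; one three-membered non-aromatic ring of carbon only, one five-membered non-aromatic ring with 1 hetero atom) in place of a group of 8 heavy atoms (5 carbon, 3 nitrogen; one five-membered aromatic ring with 2 hetero atoms), on an aromatic carbon. The whole methyl(1-methyl-1H-pyrazol-3-yl)amino group leaves the aromatic carbon, and the group that enters has only non-aromatic rings. For the measured compounds named here, the one measured step exchanged one five-membered aromatic ring for another, so it offers only weak guidance here. Going by the values given here, no measured compound carries a group like the new one, and the data therefore point in neither direction. In this assay the expected outcome is no shift beyond the scatter, stated as a 1.0-fold higher number from compound 2 to compound 3 (0.01 log units; within the scatter), with real uncertainty around it. For compound 3 the estimated clearance is 30 mL/min/kg, within an expected range of 14 mL/min/kg to 60 mL/min/kg.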

Compound 3, clearance: 23 mL/min/kg
Estimate against measurement, compound 3: 1.3-fold (0.12 log units) above, and the stated range covers the measured number.
By their numbers in this assay, from the lowest: compounds 3, 1 and 2 (each within the scatter of the next).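

In this assay, the whole methyl(1-methyl-1H-pyrazol-3-yl)amino group gives way to a group with only non-aromatic rings, and this produces a 1.3-fold lower number from compound 2 to compound 3 (0.10 log units; within the scatter). The matching exchange for the group carrying the 1,3-oxazol-2-yl ring produces a 1.3-fold lower number from compound 1 to compound 3 (0.10 log units; within the scatter), so neither step moves beyond the scatter. The earlier step only swapped one five-membered aromatic ring for another, whereas these steps show that clearance at this aromatic carbon stays within the scatter even when the aromatic ring is replaced by a three-membered ring of carbon only and a five-membered non-aromatic ring with a carbonyl.

The compounds shown leave open whether a simple amine, a methoxy group or an open-chain amide on this same aromatic carbon would also leave clearance within the scatter, or whether some groups here would shift it clearly. They also leave open why these different groups give such similar values, as no measurement shown here bears on that question.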